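Sulfanyl in Place of Chloro: Expecting Another Limit

The source may hold more compounds than are shown below. What is called first, only, known or untested is meant among the compounds shown, and "the series" means these compounds.

Compound 1 `CC(=O)OCCOn1cnc2c(Cl)nc(N)nc21` is one of three related compounds tested in a functional assay on HT-29 cells (Homo sapiens) for inhibition (a higher number here means a weaker inhibitor, a lower number a stronger inhibitor), and all three came back only at the ceiling of the assay. In this assay compound 1 gives > 500000 nM, a limit rather than a number. Compound 2 `CC(=O)OCCOn1cnc2c(Cl)nc(I)nc21` gives > 500000 nM, also a limit. Compound 3 `COc1nc(I)nc2c1ncn2OCCO` gives > 500000 nM, likewise a limit. Going by the values given here, the one measured step, a step that the two limits leave unreadable from compound 1 to compound 2, cannot be read in size because of the limit of > 500000 nM in this assay, at which 3 of the 3 values shown sit. Compound 4 `CC(=O)OCCOn1cnc2c(S)nc(N)nc21` differs from compound 1 by sulfanyl in place of chloro on an aromatic carbon. Among the compounds with values here, no measured step shows how such a change moves the read-out; all that is known is where compound 1 sits. Compound 4 is therefore expected to give about 500000 nM, within 100000 nM to 2000000 nM, most likely again as a limit. The expected step is a number no higher from compound 1 to compound 4 (the limit leaves the size open), nothing beyond the scatter.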

Compound 4, half-maximal inhibitory concentration: > 500000 nM
Compound 4: no number, only a limit; the forecaster's own chance of this, stated with the estimate: 85%; the middle value lies on the limit itself.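

Compound 1 and compound 4 both stop at a limit, so the step between them cannot be read: the limit of > 500000 nM in this assay, at which 4 of the 4 values shown sit.

In this assay the compounds shown leave open how strongly each one inhibits, and whether sulfanyl in place of chloro changes that at all.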